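The source may hold more compounds than are shown below. What is called first, only, known or untested is meant among the compounds shown, and "the series" means these compounds.

Working notes on the series in an in vitro ADME assay on microsomes from liver (Rattus norvegicus) for metabolic stability, read by LC-MS, tested at 0.05 uM; on this read-out higher numbers stand for fast clearance and lower numbers for slow clearance.

Among the compounds with values here, compound 3 `COc1cnc(-c2ccccn2)nc1NCc1ccccc1C` gives 791 mL/min/kg and stands second highest of the three numbers so far. Its nearest neighbour is compound 1 `COc1cnc(-c2ccccn2)nc1NCc1ccccc1Cl`, which gives 827 mL/min/kg; the two numbers sit within the scatter of each other, so no order between them is claimed. Furthest away is compound 2 `COc1cnc(-c2ccccn2)nc1NC1CCCC1`, which gives 202 mL/min/kg, a number that lies beyond the scatter from that of compound 3 and marks compound 2 as the only slow-clearance member of the set. Compound 2 carries a saturated ring on the amine in place of the benzyl-type group of the other two.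

The next compound, compound 4 `COc1cnc(-c2ccccn2)nc1NCc1ccccc1`, differs from compound 3 in one place: hydrogen in place of methyl on an aromatic carbon.

Within the data shown here, only one measured step bears on this position. The step of a 1.0-fold lower number from compound 1 to compound 3 (0.02 log units; within the scatter) exchanged one small group for another at the same carbon and changed nothing beyond the scatter, so this carbon has so far looked insensitive in this assay. Among the measured compounds shown here, removing the methyl outright is a further move for which no direct precedent exists in the set; the expectation is therefore anchored on compound 3, with a 1.1-fold lower number from compound 3 to compound 4 (0.05 log units; within the scatter) expected to be small. Compound 4 is estimated at 700 mL/min/kg, within a range of 350 mL/min/kg to 1400 mL/min/kg.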

Compound 4, clearance: 387 mL/min/kg
Estimate against measurement, compound 4: 1.8-fold (0.26 log units) above; the measured number falls inside the stated range.
By their numbers in this assay, from the lowest: compounds 2 and 4 (each within the scatter of the next); then compounds 3 and 1 (each within the scatter of the next).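

In this assay this carbon is less indifferent than the earlier exchange of chloro for methyl suggested (a 1.0-fold lower number from compound 1 to compound 3 (0.02 log units; within the scatter)): with hydrogen there, the number moves modestly but beyond the scatter, both against the methyl (a 2.0-fold lower number from compound 3 to compound 4 (0.31 log units; beyond the scatter)) and against the chloro (a 2.1-fold lower number from compound 1 to compound 4 (0.33 log units; beyond the scatter)), so the two substituted compounds read alike and the plain phenyl stands apart from them. The change of amine substituent from cyclopentyl to benzyl stays within the scatter (a 1.9-fold higher number from compound 2 to compound 4 (0.28 log units; within the scatter)), so compound 2 no longer stands alone at the slow-clearance end, and among these compounds the high numbers go with a group on this aromatic carbon rather than with the benzyl as such. Nothing at hand explains why removing the group shifts the number in this way.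

Only methyl, chloro and hydrogen are shown at this carbon, so it remains open whether a methoxy, a trifluoromethyl or a nitrile would read with compound 3 or with compound 4. From the compounds shown here alone, it also remains open whether a methyl or chloro elsewhere on the six-membered ring would give the same high numbers, or whether the effect belongs to this carbon alone.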